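A few compounds are considered here, and "the series" means these few. Any claim that something is new, unique, unknown or untested is made for them only; others in the source may bear on it.

Measured compounds:
compound 1 `C[C@H](NC(=O)OCc1ccccc1)C(=O)N[C@@H]1C(=O)N2CCO[C@H]12`: 38000 nM
compound 2 `CC(C)[C@H](NC(=O)OCc1ccccc1)C(=O)N[C@@H]1C(=O)N2CCO[C@H]12`: 600 nM

For the measured compounds named here, in an assay on isolated protein for inhibition of Procathepsin L (Rattus norvegicus) (a higher number here means a weaker inhibitor, a lower number a stronger inhibitor), compound 2 gives the lowest of the two numbers so far; its nearest neighbour is compound 1, separated by the step of a 63-fold lower number from compound 1 to compound 2 (1.80 log units; beyond the scatter). That step is the only measured one in the series and concerns the same place as the change now considered: a saturated chain carbon bound to an amide-type nitrogen and a carbonyl carbon.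

Compound 3 `O=C(N[C@H](C(=O)N[C@@H]1C(=O)N2CCO[C@H]12)c1ccccc1)OCc1ccccc1` has not yet been measured in this assay. It differs from compound 2 by phenyl in place of isopropyl on a saturated chain carbon bound to an amide-type nitrogen and a carbonyl carbon. Going by the values given here, the one step that bears on this change is the enlargement from compound 1 to compound 2, which was large and went toward a lower number. Whether a further enlargement to phenyl continues in that direction cannot be read from two compounds; the step from compound 1 to compound 2 shows only that this place is sensitive to the group carried. For compound 3 the expectation is therefore a number near that of compound 2, with a wide range on both sides, expressed as the step of a 2.5-fold higher number from compound 2 to compound 3 (0.40 log units; beyond the scatter). The estimate for compound 3 in this assay is 1500 nM, expected to lie between 200 nM and 10000 nM.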

Compound 3, half-maximal inhibitory concentration: 1830 nM
Beside the measured number, compound 3's estimate is 1.2-fold (0.09 log units) below it; the measured number falls inside the stated range.
By their numbers in this assay, from the lowest: compound 2; then compound 3; then compound 1.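

In this assay, phenyl does not carry on the direction set by the enlargement from methyl to isopropyl: the change gives a 3.1-fold higher number from compound 2 to compound 3 (0.48 log units; beyond the scatter), so among these compounds the group with more heavy atoms does not give the lower number, and compound 3 goes against any simple rule based on size. Phenyl nevertheless retains much of the gain over methyl, with a 21-fold lower number from compound 1 to compound 3 (1.32 log units; beyond the scatter), which places both larger groups well clear of methyl at this saturated chain carbon bound to an amide-type nitrogen and a carbonyl carbon, with isopropyl giving the lowest number of the three. No measured information is available to account for this ordering.

The three groups compared do not separate the effect of an aromatic ring from that of size or branching; a cyclohexyl group at the same place would set a saturated ring directly against phenyl, while a benzyl group or a longer chain such as isobutyl would test whether added length changes the number. Going by these compounds, how this place responds to a group carrying an amine or a carboxylic acid also remains open.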